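Taking a methoxy group off compound 2

The source may hold more compounds than are shown below. What is called first, only, known or untested is meant among the compounds shown, and "the series" means these compounds.

In a physicochemical assay for acid dissociation, compound 1 (`COc1ccnc(C[S+]([O-])c2nc3cc(OCC(F)(F)F)ccc3[nH]2)c1OC`) gives 3.9. Compound 2 (`COc1cnc(C[S+]([O-])c2nc3cc(OCC(F)(F)F)ccc3[nH]2)c(C)c1OC`) gives 3.72, and these two numbers lie within the scatter of each other, so the pair does not separate. Compound 3 (`COc1ccnc(C[S+]([O-])c2nc3cc(OCC(F)(F)F)ccc3[nH]2)c1C`) differs from compound 2 in one place: hydrogen in place of methoxy on an aromatic carbon, with hydrogen in place of methoxy on an aromatic carbon. Among the compounds with values here, no measured pair shows this change on its own, so its size in this assay remains a matter of judgement. A small rise is expected, about as large as the scatter or slightly larger, with the proton given up somewhat less readily. The expected shift is a number 0.33 log units higher from compound 2 to compound 3 (beyond the scatter). For compound 3 the estimated value is 4.05, with an expected range from 3.75 to 4.4.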

Compound 3, acid dissociation constant: 4.97
Compound 3: middle estimate off by 0.92 log units, on the low side; measured number above the stated range.
By their numbers in this assay, from the lowest: compounds 2 and 1 (each within the scatter of the next); then compound 3.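

In this assay, compound 1 and compound 2 had stood within the scatter of each other, and nothing yet showed that this part of the molecule could move the number much. Hydrogen in place of methoxy, on the aromatic carbon two atoms from the ring nitrogen, gives a number 1.25 log units higher from compound 2 to compound 3 (beyond the scatter), and methyl in place of methoxy on an aromatic carbon gives a number 1.07 log units higher from compound 1 to compound 3 (beyond the scatter), so both single changes leading to compound 3 are large and set it apart from both neighbours. Nothing measured here accounts for the size of these steps.

The compounds shown leave open how an amine or a longer chain would read on that same aromatic carbon. They also leave open whether a step of this size would recur if methoxy were removed from a different core.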